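Saturating the side chain across two shared cores

A few compounds are considered here, and "the series" means these few. Any claim that something is new, unique, unknown or untested is made for them only; others in the source may bear on it.

Compound 1 `CCCCC/C=C\C/C=C\CCCCCCCC1(O)CC(=O)c2c(O)cc(OCOC)cc2O1` carries a deca-1,4-dien-1-yl side chain on a saturated core. In a functional assay on MCF7 cells (Homo sapiens) for antiproliferative activity, read by MTT assay (on this read-out lower numbers stand for stronger inhibition and higher numbers for weaker inhibition), compound 1 gives only a limit, > 84100 nM. Compound 3 `CCCCCCCCCCCCCCCC1(O)CC(=O)c2c(O)cc(OCOC)cc2O1` is its saturated counterpart, (octyl in place of deca-1,4-dien-1-yl on a saturated chain carbon, seven bonds along the chain from a saturated ring carbon). In this assay compound 3 likewise gives only a limit, > 67200 nM. The step that the two limits leave unreadable from compound 1 to compound 3 cannot be sized, since both values sit at limits (the limit of > 67200 nM in this assay, at which 1 of the 3 values shown sits, (the limit of > 84100 nM in this assay, at which 2 of the 3 values shown sit)).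

Compound 2 `CCCCC/C=C\C/C=C\CCCCCCCc1cc(=O)c2c(O)cc(OCOC)c(C)c2o1` rests on a different core; the difference between the two cores is not broken down here. In this assay compound 2 gives only a limit, > 84100 nM.

Compound 4 `CCCCCCCCCCCCCCCc1cc(=O)c2c(O)cc(OCOC)c(C)c2o1` is still to be measured in this assay and relates to compound 2 by the same kind of change, (octyl in place of deca-1,4-dien-1-yl on a saturated chain carbon, seven bonds along the chain from an aromatic carbon); here the place is seven bonds along the chain from an aromatic carbon rather than from a saturated ring carbon. Because the saturation from compound 1 to compound 3 left both values at limits (the limit of > 67200 nM in this assay, at which 1 of the 3 values shown sits, (the limit of > 84100 nM in this assay, at which 2 of the 3 values shown sit)), compound 4 is expected to stay out of range as well, an estimated step that the limit leaves unreadable from compound 2 to compound 4. The estimate for compound 4 is 100000 nM, between 50000 nM and 250000 nM.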

Compound 4, half-maximal inhibitory concentration: > 67200 nM
Compound 4: a limit, no number; the forecaster's own chance of this, stated with the estimate: 85%; the middle value is on the limit's open side.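

In this assay compound 2 and compound 4 both stand only as limits, and no step can be read between them for octyl in place of deca-1,4-dien-1-yl. The compounds shown leave open whether either side chain, on either core, gives any measurable antiproliferative activity in these cells, and how the two chains would compare.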